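Ketoamide series: hydroxy in place of decylamino

A few compounds are considered here, and "the series" means these few. Any claim that something is new, unique, unknown or untested is made for them only; others in the source may bear on it.

In an assay on isolated protein (Oryctolagus cuniculus) for inhibition of Calpain-2 catalytic subunit (Homo sapiens), at pH 8.0 (on this read-out lower numbers stand for stronger inhibition and higher numbers for weaker inhibition), compound 1 `CCOC(=O)C(=O)C(CC)NC(=O)C(CC(C)C)NC(=O)OCc1ccccc1` gives 400 nM. In this assay, among the measured compounds shown here, compound 2 `CCCCCCCCCCNC(=O)C(=O)C(CC)NC(=O)C(CC(C)C)NC(=O)OCc1ccccc1` gives 600 nM; its only neighbour among the measured numbers is compound 1, and the step of a 1.5-fold higher number from compound 1 to compound 2 (0.18 log units; within the scatter) lies within the scatter. Compound 3 `CCC(NC(=O)C(CC(C)C)NC(=O)OCc1ccccc1)C(=O)C(=O)O` carries hydroxy in place of decylamino on a carbonyl carbon. For the measured compounds named here, the one step that bears on this carbonyl carbon is a 1.5-fold higher number from compound 1 to compound 2 (0.18 log units; within the scatter), which moved the number little; no measured compound carries a hydroxy there, so the expectation rests on that single step and stays uncertain. A step of a 2.0-fold higher number from compound 2 to compound 3 (0.30 log units; within the scatter) is expected. Compound 3 is estimated at 1200 nM, within a range of 250 nM to 6000 nM.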

Compound 3, inhibition constant: 22 nM
Beside the measured number, compound 3's estimate is 55-fold (1.74 log units) above it; measured number outside the range, below it.
By their numbers in this assay, from the lowest: compound 3; then compounds 1 and 2 (each within the scatter of the next).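

In this assay this carbonyl carbon proves sensitive to its substituent: hydroxy gives a 27-fold lower number from compound 2 to compound 3 (1.44 log units; beyond the scatter) and an 18-fold lower number from compound 1 to compound 3 (1.26 log units; beyond the scatter) where the exchange of ethoxy for decylamino had stayed within the scatter. The position therefore sets hydroxy apart from both ethoxy and decylamino, a separation that the earlier pair gave no sign of. Going by these compounds, whether an unsubstituted amino group or a methoxy at this carbon keeps any of the gain remains open, as does whether it carries over to other side chains on the shared core. No evidence on hand accounts for the gain.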